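This account rests on a few compounds, and the source may have more. Where it says the series, first, only, none or still open, it means among the compounds named here.

In a functional assay on CHO cells for agonist activity at Alpha-1A adrenergic receptor (Homo sapiens), read by FLIPR and calcium flux (on this read-out higher numbers stand for an effect only at larger amounts of compound and lower numbers for an effect already at smaller amounts), compound 1 `COc1c(Cl)ccc2c1CCC2c1ncc[nH]1` gives 451 nM and compound 3 `COc1c(C)ccc2c1CCC2c1ncc[nH]1` gives 167 nM. Within the data shown here, the single measured step between neighbours is a 2.7-fold lower number from compound 1 to compound 3 (0.43 log units; beyond the scatter). Compound 2 `Cn1cc(-c2cccc3c2CCC3c2ncc[nH]2)cn1` sits at the limit of > 2900 nM in this assay, at which 1 of the 3 values shown sits, a limit of the assay rather than a number, and in this assay compound 2 gives > 2900 nM. Compound 4 `c1cc(-c2ncco2)c2c(c1)C(c1ncc[nH]1)CC2` differs from compound 2 in one place: 1,3-oxazol-2-yl in place of 1-methyl-1H-pyrazol-4-yl on an aromatic carbon. Among the measured compounds shown here, no measured step swaps one five-membered aromatic ring for another; the chloro-to-methyl step concerns a different group and offers no guide here. Compound 2 is known only as a limit, which leaves the starting point uncertain. Compound 4 is therefore expected near 3000 nM, within a range from 700 nM to 13000 nM. The implied step is estimated as a step that the limit leaves unreadable from compound 2 to compound 4.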

Compound 4, half-maximal effective concentration: 170 nM
Beside the measured number, compound 4's estimate is 18-fold (1.25 log units) above it; the measured number lies below the stated range.
By their numbers in this assay, from the lowest: compounds 3 and 4 (each within the scatter of the next); then compound 1. At a limit, above all of these: compound 2.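

In this assay, exchanging one five-membered aromatic ring for another on this aromatic carbon gives an at least 17-fold lower number from compound 2 to compound 4 (1.23 log units; beyond the scatter), so the identity of the ring here clearly matters. The two rings have matching counts of hetero atoms, hydrogen-bond donors and hydrogen-bond acceptors, so those counts alone do not separate them. Compound 2 is known only as a limit, not a number: the limit of > 2900 nM in this assay, at which 1 of the 4 values shown sits.

From the compounds shown here alone, the true size of the step therefore stays open. Also open, going by these compounds, is how this aromatic carbon would respond to an amine or a carboxylic acid in place of either ring.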